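Larger aromatic ketone on the shared core

The source may hold more compounds than are shown below. What is called first, only, known or untested is meant among the compounds shown, and "the series" means these compounds.

Of the compounds shown here, three built on one shared core have been measured in a functional assay on PC-3 cells (Homo sapiens) for cytotoxicity, read by MTT assay, with a stated time of 48 h; on this read-out lower numbers stand for stronger inhibition and higher numbers for weaker inhibition. Compound 1 `COc1cc(-c2nnc3n2NC(c2ccco2)C(C(=O)c2ccc(Br)cc2)S3)cc(OC)c1OC` gives 36400 nM. Compound 3 `COc1cc(-c2nnc3n2NC(c2ccco2)C(C(=O)c2ccc(C(F)(F)F)cc2)S3)cc(OC)c1OC` gives 77500 nM, the highest of the two numbers recorded; its nearest neighbour is compound 1, with a 2.1-fold higher number from compound 1 to compound 3 (0.33 log units; beyond the scatter). Compound 2 `COc1cc(-c2nnc3n2NC(c2ccco2)C(C(=O)c2cccc4ccccc24)S3)cc(OC)c1OC` reaches only a limit of this assay, (the limit of > 100000 nM in this assay, at which 1 of the 3 values shown sits), and is recorded as > 100000 nM.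

Compound 4 `COc1cc(-c2nnc3n2NC(c2ccco2)C(C(=O)c2ccc(-c4ccccc4)cc2)S3)cc(OC)c1OC` differs from compound 3 by phenyl in place of trifluoromethyl on an aromatic carbon. The step that bears most on this change is an at least 2.7-fold higher number from compound 1 to compound 2 (0.43 log units; beyond the scatter), in which a larger aromatic group on the carbonyl carbon carried the number past the limit of this assay, while an at least 1.2-fold lower number from compound 2 to compound 3 (0.11 log units; that floor lies within the scatter) stayed within the scatter. An upward step in this assay is therefore expected for compound 4, a 1.2-fold higher number from compound 3 to compound 4 (0.09 log units; within the scatter), with a real chance that only a limit is reported. Compound 4 is estimated to give 95000 nM, within a range from 45000 nM to 200000 nM.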

Compound 4, half-maximal inhibitory concentration: 45900 nM
The estimate for compound 4 lay 2.1-fold (0.32 log units) above the measured number; low and high end bracket the measured number.
By their numbers in this assay, from the lowest: compounds 1, 4 and 3 (each within the scatter of the next, the first and the last beyond it). At a limit, above all of these: compound 2.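

In this assay, phenyl in place of trifluoromethyl gives a 1.7-fold lower number from compound 3 to compound 4 (0.23 log units; within the scatter), and phenyl in place of bromo gives a 1.3-fold higher number from compound 1 to compound 4 (0.10 log units; within the scatter), so an added ring on this aromatic carbon, para to a large group, gives no change that stands clear of the scatter. Greater size in the aromatic ketone therefore does not by itself go with a higher number, as an at least 2.1-fold lower number from compound 2 to compound 4 (0.33 log units; beyond the scatter) shows, with compound 2 as the one case that still sits apart. That comparison has only a floor, since compound 2 stays at a limit and not at a number: the limit of > 100000 nM in this assay, at which 1 of the 4 values shown sits.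

The compounds shown leave open whether an amine or a carboxylic acid on this aromatic carbon would shift the number. They also leave open whether naphthalen-2-yl on the carbonyl carbon would behave like naphthalen-1-yl or like 4-phenylphenyl.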